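One Aryl Swap Measured Once, Expected Again

This account rests on a few compounds, and the source may have more. Where it says the series, first, only, none or still open, it means among the compounds named here.

Measured compounds:
compound 1 `Cc1ccccc1/C(CCN1CCN(c2ccccn2)CC1)=N/O`: 82%
compound 2 `O/N=C(\CCN1CCN(c2ccccn2)CC1)c1ccc(Cl)cc1`: 46%
compound 3 `CO/N=C(\CCN1CCN(c2ccccn2)CC1)c1ccccc1C`: 80%

All three were tested in a functional assay on HEK293 cells with D(4) dopamine receptor (Homo sapiens) as the target, read by FLIPR; on this read-out lower numbers stand for smaller maximal responses and higher numbers for larger maximal responses. Compound 1 and compound 3 share a core and differ only by methyl in place of hydrogen on an oxygen; the step of a number 2 percentage points lower from compound 1 to compound 3 (within the scatter) lies within the scatter, so the two cores are not told apart by this read-out. The second difference is larger: compound 2 is built from compound 1 by 4-chlorophenyl in place of 2-methylphenyl on a carbon with a double bond to nitrogen, and the step of a number 36 percentage points lower from compound 1 to compound 2 (beyond the scatter) is well beyond the scatter.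

Compound 4 `CO/N=C(\CCN1CCN(c2ccccn2)CC1)c1ccc(Cl)cc1` has not yet been measured. It comes from compound 3 by 4-chlorophenyl in place of 2-methylphenyl on a carbon with a double bond to nitrogen. The place of this change is the same, word for word, as the place of the change from compound 1 to compound 2, so it is the same change, made on the other core.

For compound 4 the expected step is a number 36 percentage points lower from compound 3 to compound 4 (beyond the scatter), resting on the earlier step of a number 36 percentage points lower from compound 1 to compound 2 (beyond the scatter) and on the fact that compound 3 gave 80%, close to compound 1. Compound 4 is therefore estimated at 44%, expected to fall between 30% and 60%.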

Compound 4, largest response reached (reported as efficacy), in percent of the reference or control that the assay uses: 87%
Beside the measured number, compound 4's estimate is 43 percentage points below it; measured number outside the range, above it.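

In this assay, placing 4-chlorophenyl on the core of compound 3 gave a number 7 percentage points higher from compound 3 to compound 4 (within the scatter), so the large step seen on the core of compound 1 did not carry over: the same change on two cores in this assay, a number 36 percentage points lower (beyond the scatter) from compound 1 to compound 2 and a number 7 percentage points higher (within the scatter) from compound 3 to compound 4, 43 percentage points apart, beyond the scatter of two such steps. Read the other way, methyl in place of hydrogen on an oxygen gave a number 41 percentage points higher from compound 2 to compound 4 (beyond the scatter), although the same change had made no difference beyond the scatter with 2-methylphenyl in place, so the outcome of each change depends on the other here: the same change on two cores in this assay, a number 2 percentage points lower (within the scatter) from compound 1 to compound 3 and a number 41 percentage points higher (beyond the scatter) from compound 2 to compound 4, 43 percentage points apart, beyond the scatter of two such steps. This does not show why the two changes depend on each other, and both comparisons rest on the same four compounds, with the low value of compound 2, 46%, entering each.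

As far as these compounds go, it remains open whether an ethyl group on the oxygen, or a plain phenyl or 4-methoxyphenyl group on the carbon with a double bond to nitrogen, would behave like compound 2 or like compound 4. From the compounds shown here alone, a longer saturated chain at that carbon is equally open.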